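The compounds below may be only part of what the source reports. "The series", "measured", "known", "first", "only" and "open" are said of these compounds alone.

In a functional assay on MDA-MB-231 cells (Homo sapiens) for inhibition, read by MTT assay, with a stated time of 72 h (on this read-out higher numbers stand for weaker inhibition and lower numbers for stronger inhibition), compound 3 `C=CC(=O)Nc1cccc(NC(=O)CSc2nc(Nc3cccc(Cl)c3)c3ccccc3n2)c1` gives 16300 nM. Its two companions sit within the scatter of that figure: compound 1 `C=CC(=O)Nc1cccc(NC(=O)CSc2nc(Nc3ccccc3F)c3ccccc3n2)c1` gives 18700 nM in this assay, and compound 2 `C=CC(=O)Nc1cccc(NC(=O)CSc2nc(Nc3ccccc3C)c3ccccc3n2)c1` gives 20400 nM. The steps joining them are all small, namely a 1.1-fold higher number from compound 1 to compound 2 (0.04 log units; within the scatter), a 1.1-fold lower number from compound 1 to compound 3 (0.06 log units; within the scatter) and a 1.3-fold lower number from compound 2 to compound 3 (0.10 log units; within the scatter), so the three numbers cannot be told apart.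

Compound 4 `C=CC(=O)Nc1cccc(NC(=O)CSc2nc(Nc3cccc(Br)c3)c3ccccc3n2)c1` differs from compound 3 by bromo in place of chloro on an aromatic carbon. Within the data shown here, none of the measured steps exchanges one halogen for another; the nearest are the variations of the aryl group on the amino nitrogen, each within the scatter. On that basis the change is expected to carry no step beyond the scatter, a 1.1-fold lower number from compound 3 to compound 4 (0.04 log units; within the scatter). The value of compound 4 in this assay is therefore estimated at 15000 nM, with a range from 7000 nM to 32000 nM.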

Compound 4, half-maximal inhibitory concentration: 19400 nM
The estimate for compound 4 lay 1.3-fold (0.11 log units) below the measured number, and the stated range covers the measured number.
By their numbers in this assay, from the lowest: compounds 3, 1, 4 and 2 (each within the scatter of the next).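

Bromo and chloro at this place on the ring can now be compared directly: in this assay the exchange gives a 1.2-fold higher number from compound 3 to compound 4 (0.08 log units; within the scatter) and so does not separate the 3-chlorophenyl and 3-bromophenyl groups. The 3-bromophenyl group also stays level with both groups carrying a substituent elsewhere on the ring, with a 1.1-fold lower number from compound 2 to compound 4 (0.02 log units; within the scatter) for the exchange from 2-methylphenyl and a 1.0-fold higher number from compound 1 to compound 4 (0.02 log units; within the scatter) for the exchange from 2-fluorophenyl, so all four aryl groups on the amino nitrogen remain indistinguishable in this assay. No measurement is available to explain this lack of separation.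

From the compounds shown here alone, it remains open whether an amine or a carboxylic acid in place of the halogen would produce a step beyond the scatter. Going by these compounds, the effect of replacing the acrylamide with a saturated propanamide also remains open.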